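Changing the Ester Chain and Watching Cytotoxicity

The source may report more compounds than this note shows. Statements on the series, on what has been measured and on what is new or still open speak of the compounds shown alone.

Compound 1 `CCCCOC(=O)C(O)Cn1cnc2c(N)ncnc21` and compound 2 `COCCOC(=O)C(O)Cn1cnc2c(N)ncnc21` share one core and differ only in the chain carried on an oxygen next to a carbonyl group. In a functional assay on PRK cells (Oryctolagus cuniculus) for cytotoxicity (on this read-out higher numbers stand for lower toxicity in this test and lower numbers for higher toxicity in this test), compound 1 gives 200 ug/mL. Compound 2 reaches only a limit of this assay, > 400 ug/mL, so its true value is not known as a number. Going by these compounds, the change from compound 1 to compound 2, methoxy in place of ethyl on a saturated chain carbon, brought an at least 2.0-fold higher number from compound 1 to compound 2 (0.30 log units; that floor lies within the scatter); because the limit of > 400 ug/mL in this assay, at which 1 of the 2 values shown sits, the upper size of this step stays open. Compound 3 `CC(C)(C)OC(=O)C(O)Cn1cnc2c(N)ncnc21` carries yet another group at that oxygen: tert-butyl in place of 2-methoxyethyl on an oxygen next to a carbonyl group. For the measured compounds named here, the single measured step is the only guide, and it suggests little movement beyond the scatter in this assay. Compound 3 is therefore expected to sit near the limit at 400 ug/mL, within a range of 150 ug/mL to 800 ug/mL, which amounts to an expected step of a number no higher from compound 2 to compound 3 (the limit leaves the size open).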

Compound 3, minimum cytotoxic concentration: > 400 ug/mL
Compound 3: a limit, no number; the forecaster's own chance of this, stated with the estimate: 50%; the middle value sits exactly at the limit.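

In this assay compound 3 also gives only a limit, > 400 ug/mL, not a number. The ether oxygen of 2-methoxyethyl is therefore not required to reach this limit, since tert-butyl, with the same count of 4 heavy atoms but no hydrogen-bond acceptor, reaches it too; swapping butyl for tert-butyl gives an at least 2.0-fold higher number from compound 1 to compound 3 (0.30 log units; that floor lies within the scatter), so this change cannot be told apart from scatter. No step can be read between the two compounds at the limit, because neither has a number: the limit of > 400 ug/mL in this assay, at which 2 of the 3 values shown sit.

Going by these compounds, how far compound 2 and compound 3 truly lie beyond the limit stays open. So does whether a longer chain such as octyl, or a chain ending in an amine or a carboxylic acid, would give a number lower than that of compound 1.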